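Aryl sulfonyl variation on the shared core

The source may report more compounds than this note shows. Statements on the series, on what has been measured and on what is new or still open speak of the compounds shown alone.

Measured so far:
Compound 1, `CC1CCN(C2CCN(S(=O)(=O)c3cccc4cnccc34)CC2)CC1`: in a functional assay on DLD-1 cells (Homo sapiens) for antiproliferative activity, read by CellTiter-Glo, with a stated time of 72 h (on this read-out lower numbers stand for stronger inhibition and higher numbers for weaker inhibition), compound 1 gives 225 nM.
Compound 2, `Cc1nc(Cl)sc1S(=O)(=O)N1CCC(N2CCC(C)CC2)CC1`: in this assay compound 2 gives 1.6 nM.
Compound 3, `COc1ccc(-c2ccc(S(=O)(=O)N3CCC(N4CCC(C)CC4)CC3)cc2)cc1`: in this assay compound 3 gives 263 nM.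

Compound 2 stands lowest of the three numbers in this assay. Its nearest neighbour is compound 1, and the gap between them is beyond the scatter; compound 3 sits further still, also beyond the scatter. Among the three, the only sulfonyl substituent that is a five-membered ring with hetero atoms belongs to compound 2; the two six-membered carbon ring systems in compound 1 and compound 3 both give much higher numbers.

The next compound, compound 4, `CC1CCN(C2CCN(S(=O)(=O)c3cccc(Cl)c3)CC2)CC1`, is drawn from compound 2 by one change: 3-chlorophenyl in place of 2-chloro-4-methyl-1,3-thiazol-5-yl on a sulfonyl sulfur. Going by the values given here, no measured pair shows this exact change. Because compound 1 gives 225 nM and compound 3 gives 263 nM, both carrying six-membered carbon rings on the sulfonyl sulfur, a sizeable rise in this assay is expected for the step, well beyond the scatter, rather than none.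

Compound 4 is therefore expected at 120 nM, within 25 nM to 600 nM, an expected step of a 75-fold higher number from compound 2 to compound 4 (1.88 log units; beyond the scatter).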

Compound 4, half-maximal inhibitory concentration: > 5000 nM
Compound 4: a limit, no number; the forecaster's own chance of this, stated with the estimate: 5%; at least 41-fold (1.61 log units) between middle value and limit.
By their numbers in this assay, from the lowest: compound 2; then compounds 1 and 3 (each within the scatter of the next). At a limit, above all of these: compound 4.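

In this assay compound 4 gives > 5000 nM, a limit of the assay and not a number: the limit of > 5000 nM in this assay, at which 1 of the 4 values shown sits.

3-Chlorophenyl in place of 2-chloro-4-methyl-1,3-thiazol-5-yl on the sulfonyl sulfur gives an at least 3100-fold higher number from compound 2 to compound 4 (3.49 log units; beyond the scatter), so this position does not tolerate the exchange, although both groups count 7 heavy atoms. Both groups also carry a chlorine, so a chlorine on an aromatic ring at this sulfonyl sulfur is not enough to keep the low number of compound 2.

Open, as far as these compounds go, is whether that low number needs the ring hetero atoms, the methyl or the chlorine of the 2-chloro-4-methyl-1,3-thiazol-5-yl group. Also open, from the compounds shown here alone, is how a thiophene, or a thiazole carrying an amine in place of the chlorine, would read at the same sulfonyl sulfur.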